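A few compounds are considered here, and "the series" means these few. Any claim that something is new, unique, unknown or untested is made for them only; others in the source may bear on it.

Compound 1 `Oc1ccc(-c2cc(-c3cccc(Cl)c3)nc(-c3ccccn3)c2)cc1` — 0%
Compound 2 `Oc1cccc(-c2cc(-c3cccc(Cl)c3)nc(-c3ccccn3)c2)c1` — "not determined" (no result reported)
Compound 3 `Oc1ccc(-c2cc(-c3ccc(Cl)cc3)nc(-c3ccccn3)c2)cc1` — "not determined" (no result reported)

Three compounds share the same core, but only one of them has a number. In an assay on isolated protein for inhibition of DNA topoisomerase 1 (Homo sapiens), with a stated time of 30 min, tested at 20 uM (a lower number here means a weaker effect, a higher number a stronger effect of the compound at the concentration tested), compound 1 gives 0%, which is no measurable effect at the concentration tested. Compound 2 comes with "not determined" (no result reported) and compound 3 comes with "not determined" (no result reported), so compound 1 stands alone as the sole reference, with nothing to rank it against.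

Compound 4 `Oc1ccc(-c2cc(-c3cccc(Cl)c3)nc(-c3cccs3)c2)cc1` is the next compound to be measured. It differs from compound 1 in one place: thiophen-2-yl in place of pyridin-2-yl on an aromatic carbon. For the measured compounds named here, no step between two measured compounds is available that would show how such a change plays out on this core.

Going by the values given here, with compound 1 giving 0%, the starting point shows no measurable effect at the concentration tested, and no measured step shows whether the swap helps. The step of a number 5 percentage points higher from compound 1 to compound 4 (within the scatter) is therefore expected to be small, a modest rise at most, and likely within the scatter of repeated measurements. Compound 4 is expected to give 5%, with a range from 0% to 25%.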

Compound 4, a percentage reported as inhibition, at one concentration (the size of the read-out at that concentration, not a potency): 0%
Beside the measured number, compound 4's estimate is 5 percentage points above it; the range from low to high includes it.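

In this assay, for the compounds shown here, placing thiophen-2-yl where pyridin-2-yl stood on this aromatic carbon gives no change at the digits printed from compound 1 to compound 4 (within the scatter) and so offers the first direct look at this position. Exchanging a six-membered aromatic ring with a nitrogen for a five-membered one with a sulfur does not lift the read-out above the no-effect level seen for the core of compound 1 at the concentration tested. As both compounds sit at that level, the step cannot show how much this position matters, and nothing available explains the result.

Going by these compounds, it remains open whether a quite different group at this position, such as an amine or a carboxylic acid, would give a measurable effect. On these data alone, it also remains open whether a change elsewhere on the shared core would make this ring swap show up in the read-out.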